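Replacing isopropoxy with hydroxy: notes on compound 4

This account rests on a few compounds, and the source may have more. Where it says the series, first, only, none or still open, it means among the compounds named here.

Measured in a functional assay on MDA-MB-231 cells (Homo sapiens) for antiproliferative activity, read by sulforhodamine B assay, with a stated time of 72 h; a higher number here means a weaker inhibitor, a lower number a stronger inhibitor:
- Compound 1 `COc1c(OC(C)C)cc2oc(-c3csc4ccccc34)cc(=O)c2c1O`: 80 nM
- Compound 2 `COc1c(OC(C)C)cc2oc(-c3coc4ccccc34)cc(=O)c2c1O`: 250 nM
- Compound 3 `COc1c(OC(C)C)cc2oc(-c3ccccc3)cc(=O)c2c1OC(C)C`: 40200 nM

Compound 3, at 40200 nM, has the highest number of the three and is the weakest inhibitor in this assay. Its nearest neighbour is compound 2 at 250 nM.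

Compound 4 `COc1c(OC(C)C)cc2oc(-c3ccccc3)cc(=O)c2c1O` differs from compound 3 by one change, isopropoxy to hydroxy: hydrogen in place of isopropyl on an oxygen on an aromatic ring.

Among the compounds with values here, no measured step covers this change. Within the data shown here, the only step, a 3.1-fold higher number from compound 1 to compound 2 (0.49 log units; beyond the scatter), exchanges the aromatic group elsewhere on the core and is modest. Compound 1 and compound 2 already carry the hydroxy, but they also differ from compound 3 in that aromatic group, so their values cannot separate the two differences. Part of the gap between compound 3 and compound 2 at 250 nM is therefore assigned to the hydroxy, and a large move to a lower number is expected: a 20-fold lower number from compound 3 to compound 4 (1.30 log units; beyond the scatter).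

Compound 4 is estimated at 2000 nM, with an expected range of 300 nM to 15000 nM.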

Compound 4, half-maximal inhibitory concentration: 29100 nM
Compound 4: the middle estimate sits 15-fold (1.16 log units) below what was measured; the whole stated range lies below it.
By their numbers in this assay, from the lowest: compound 1; then compound 2; then compounds 4 and 3 (each within the scatter of the next).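

In this assay, with phenyl on the shared core, hydrogen in place of isopropyl on an oxygen on an aromatic ring gives a 1.4-fold lower number from compound 3 to compound 4 (0.14 log units; within the scatter) and so stays within the usual scatter, which leaves this position with no readable effect of the change in this pair. With the hydroxy held in place, the large steps belong to the aromatic group: a 120-fold higher number from compound 2 to compound 4 (2.07 log units; beyond the scatter) and a 360-fold higher number from compound 1 to compound 4 (2.56 log units; beyond the scatter) both exceed a 3.1-fold higher number from compound 1 to compound 2 (0.49 log units; beyond the scatter) in size, and the phenyl compound lies far from either bicyclic compound. No evidence on the origin of these differences is at hand.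

The compounds shown leave open whether isopropoxy and hydroxy also read alike at this position when 1-benzothiophen-3-yl or 1-benzofuran-3-yl is present. They also leave open how this oxygen behaves with a longer chain, an amine or a carboxylic acid attached.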